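The compounds below may be only part of what the source reports. "The series", "measured", "known", "first", "only" and "open" are said of these compounds alone.

Measured so far:
- compound 1 `O=c1c2ccccc2nc(-c2ccccc2)n1/N=C/c1ccc(Oc2ccc([N+](=O)[O-])cc2)cc1`: 6.12
- compound 2 `Cc1ccc(Oc2ccc(/C=N/n3c(-c4ccccc4)nc4ccccc4c3=O)cc2)cc1`: 6.29

Both compounds share one core and differ only in the group on the far aromatic ring. In a physicochemical assay for lipophilicity, in phosphate buffer, measured as octanol-water partition (on this read-out higher numbers stand for higher lipophilicity and lower numbers for lower lipophilicity), compound 1 gives 6.12 and compound 2 gives 6.29. For the measured compounds named here, the one measured step, a number 0.17 log units higher from compound 1 to compound 2 (within the scatter), is within the scatter, so compound 2 is not to be called higher than compound 1; it simply holds the larger of the two numbers.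

Compound 3 `O=c1c2ccccc2nc(-c2ccccc2)n1/N=C/c1ccc(Oc2ccc3ccccc3c2)cc1` is not yet measured. Compared with compound 2, the difference is naphthalen-2-yl in place of 4-methylphenyl on an oxygen on an aromatic ring. Going by the values given here, no measured step concerns this kind of change: the only step known, from compound 1 to compound 2, swaps a small group on the same ring and says nothing about replacing the whole ring by a larger two-ring system. The expectation therefore rests on the structural change alone, which adds three carbon atoms and a second aromatic ring. Compound 3 is expected to come out higher than compound 2 in this assay, by about a number 0.71 log units higher from compound 2 to compound 3 (beyond the scatter). The estimate for compound 3 is 7, with a range from 6.5 to 7.5.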

Compound 3, partition coefficient: 6.53
The estimate for compound 3 lay 0.47 log units above the measured number, and the stated range covers the measured number.
By their numbers in this assay, from the lowest: compounds 1, 2 and 3 (each within the scatter of the next, the first and the last beyond it).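

In this assay the group on the oxygen has now been exchanged as a whole, not just altered by a small substituent on its ring. Going from 4-methylphenyl, with 7 heavy atoms and one six-membered aromatic ring, to naphthalen-2-yl, with 10 heavy atoms and 2 such rings, gives a number 0.24 log units higher from compound 2 to compound 3 (within the scatter) and so does not separate the two groups on this read-out, even though the second ring is a sizeable structural change. Naphthalen-2-yl in place of 4-nitrophenyl gives a number 0.41 log units higher from compound 1 to compound 3 (beyond the scatter) and is the only step among these three compounds to clear the scatter, while nothing measured on these compounds accounts for its size.

From the compounds shown here alone, all three groups on this oxygen are aromatic rings made of carbon only, so it remains open how this assay would respond to a saturated ring such as cyclohexyl, or to an amine or a carboxylic acid on the ring. Also open, going by these compounds, is whether naphthalen-1-yl would read like naphthalen-2-yl, and whether a change elsewhere on the shared core would give a larger step than these.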